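The compounds below may be only part of what the source reports. "The series", "measured", "known", "first", "only" and "open" are said of these compounds alone.

Measured in a functional assay on RXF 393 cells (Homo sapiens) for inhibition, read by sulforhodamine B assay, with a stated time of 48 h, tested at 100 uM; on this read-out higher numbers stand for a weaker effect at the one concentration tested and lower numbers for a stronger effect:

- compound 1 `O=C(Nc1cccc(-n2cc(-c3ccncc3)c(-c3cc(O)cc(Cl)c3)n2)c1)Nc1ccc(Cl)c(C(F)(F)F)c1`: -72%
- compound 2 `O=C(Nc1cccc(-n2cc(-c3ccncc3)c(-c3cc(O)cc(Cl)c3)n2)c1)Nc1ccc(Cl)c(Cl)c1`: -52%

Compound 1 has the lowest of the two numbers in this assay. Within the data shown here, its only neighbour is compound 2, which is reached by a number 20 percentage points higher from compound 1 to compound 2 (beyond the scatter); the change there sits on the urea-linked aryl, not on the phenol ring.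

Compound 3 `COc1cc(Cl)cc(-c2nn(-c3cccc(NC(=O)Nc4ccc(Cl)c(C(F)(F)F)c4)c3)cc2-c2ccncc2)c1` differs from compound 1 as follows.

methyl in place of hydrogen on an oxygen on an aromatic ring

Cut one bond further out, the change reads hydroxy to methoxy, or 3-chloro-5-hydroxyphenyl to 3-chloro-5-methoxyphenyl. Among the measured compounds shown here, none of the measured steps touches this oxygen; the one measured step concerns a different ring, so it does not bear directly on the change. For the measured compounds named here, with no step on the phenol available, the expectation for compound 3 rests on compound 1 alone. A weakening is tentatively expected, with wide uncertainty, since the data give nothing to anchor the size. The estimate for compound 3 in this assay is -50%, within -85% to 0%, which is an expected step of a number 22 percentage points higher from compound 1 to compound 3 (beyond the scatter).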

Compound 3, a percentage reported as activity, at one concentration (the size of the read-out at that concentration, not a potency): -58%
Compound 3: the middle estimate sits 8 percentage points above what was measured; the range from low to high includes it.
By their numbers in this assay, from the lowest: compound 1; then compounds 3 and 2 (each within the scatter of the next).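

In this assay, among these compounds, this is the first look at the oxygen on the 3-chloro-5-hydroxyphenyl ring, and methyl in place of its hydrogen gives a modest loss (a number 14 percentage points higher from compound 1 to compound 3 (beyond the scatter)). The hydrogen on this oxygen is therefore not essential for a sizeable read-out at the one concentration tested: compound 3, with the methoxy group, still stands at a clearly negative value (-58%), although the hydroxy form of compound 1 remains ahead of it by more than the scatter. Nothing available explains the step, and the pair alone cannot separate the loss of the hydrogen from the added methyl.

From the compounds shown here alone, how far this position tolerates larger or different groups stays open, for example an ethoxy group, an amine or a carboxylic acid in place of the hydroxy group. Going by these compounds, it is also open whether the methoxy step would be of the same size with chloro in place of trifluoromethyl on the urea-linked aryl, the change that separates compound 1 from compound 2 (a number 20 percentage points higher from compound 1 to compound 2 (beyond the scatter)).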